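Polar Piperazine Dithiocarbamate Replaces the Heptyl Chain

The source may hold more compounds than are shown below. What is called first, only, known or untested is meant among the compounds shown, and "the series" means these compounds.

Compound 3 `CCCCCCCCc1cn(Cc2cc(=O)oc3cc(O)ccc23)nn1` is the point of departure. In a functional assay on HeLa cells (Homo sapiens) for inhibition, read by MTT assay, with a stated time of 72 h (a lower number here means a stronger inhibitor, a higher number a weaker inhibitor), compound 3 gives 35100 nM, the lowest of the two numbers in hand. Compound 1 `O=c1cc(Cn2cc(CCCCl)nn2)c2ccc(O)cc2o1` gives 49600 nM in this assay, and the step of a 1.4-fold lower number from compound 1 to compound 3 (0.15 log units; within the scatter) stays within the scatter, so the two cannot be ranked against each other. For compound 2 `O=c1cc(Cn2cc(CCO)nn2)c2ccc(O)cc2o1` this assay reports > 100000 nM, which is a limit and not a number (the limit of > 100000 nM in this assay, at which 1 of the 3 values shown sits). The step of an at least 2.0-fold higher number from compound 1 to compound 2 (0.30 log units; that floor lies within the scatter) and the step of an at least 2.8-fold lower number from compound 2 to compound 3 (0.45 log units; beyond the scatter) both run the same way: the compound carrying the hydroxy group sits at the weak end of the series.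

Compound 4 `O=c1cc(Cn2cc(CSC(=S)N3CCNCC3)nn2)c2ccc(O)cc2o1` has not yet been measured. It differs from compound 3 by a group of 9 heavy atoms (5 carbon, 2 nitrogen, 2 sulfur; one six-membered non-aromatic ring with 2 hetero atoms) in place of a group of 7 heavy atoms (7 carbon; no ring), on a saturated chain carbon bound to an aromatic carbon. Among the compounds with values here, the entering group brings a hydrogen-bond donor and three acceptors where the heptyl chain had none, and the only measured steps that bear on such a change, those running from and to the hydroxy-bearing compound 2, both gave higher numbers. A weaker inhibitor is therefore expected: compound 4 is estimated at 80000 nM, with a range from 30000 nM to 200000 nM. That estimate corresponds to an expected step of a 2.3-fold higher number from compound 3 to compound 4 (0.36 log units; beyond the scatter) beyond the scatter, and it is considered likely that this assay will again report only a limit for compound 4.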

Compound 4, half-maximal inhibitory concentration: > 100000 nM
Compound 4: only a limit was reported; the forecaster's own chance of this, stated with the estimate: 40%; middle value at least 1.2-fold (0.09 log units) from the limit.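

On a saturated chain carbon bound to an aromatic carbon, the result shows that a group with a six-membered non-aromatic ring and two sulfur atoms does not match the heptyl chain in this assay: the change gives an at least 2.8-fold higher number from compound 3 to compound 4 (0.45 log units; beyond the scatter). Against the chlorine-bearing chain the change gives an at least 2.0-fold higher number from compound 1 to compound 4 (0.30 log units; that floor lies within the scatter), and that floor leaves compound 1 and compound 4 unranked, so only the comparison with the heptyl chain is firm. Compound 4 is reported only as a limit, which means the weak end of the series now holds a second, very different group alongside the hydroxy of compound 2, and the step between these two compounds, limit against limit, cannot be read: the limit of > 100000 nM in this assay, at which 2 of the 4 values shown sit.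

The ring, the sulfur atoms and the ring nitrogen enter together here, so the compounds shown do not tell which of them goes with the higher number. They also leave open how a morpholine ring, a simple amine or a chain longer than heptyl would read in this place, and whether any group on this carbon can give a number clearly lower than that of compound 3.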